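A few compounds are considered here, and "the series" means these few. Any claim that something is new, unique, unknown or untested is made for them only; others in the source may bear on it.

In an ADME assay on NCM460 cells (Homo sapiens) for cytotoxicity, read by CCK-8 assay, with a stated time of 48 h (a lower number here means a stronger inhibitor, a higher number a weaker inhibitor), three compounds built on the same core have been measured. Compound 1 `COc1ccc(/C=C\c2cc(OC)c(OC)c(OC)c2)cc1OCc1ccc(CN2CC[C@H](C(=O)O)C2)cc1` gives no number, only a limit of the assay, > 50000 nM. Compound 2 `COc1ccc(/C=C\c2cc(OC)c(OC)c(OC)c2)cc1OCc1ccc(CN2CC[C@H](O)C2)cc1` gives 51000 nM. Compound 3 `COc1ccc(/C=C\c2cc(OC)c(OC)c(OC)c2)cc1OCc1ccc(CNCCNC(C)=O)cc1` gives 54000 nM, which places it within the scatter of compound 2.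

Compound 4 `COc1ccc(/C=C\c2cc(OC)c(OC)c(OC)c2)cc1OCc1ccc(CN2CC[C@@H](O)C2)cc1` follows from compound 3 with 3-hydroxypyrrolidin-1-yl in place of (2-acetamidoethyl)amino on a saturated chain carbon bound to an aromatic carbon. Within the data shown here, the one readable step that bears on this change exchanges the same two groups in the opposite direction: a 1.1-fold higher number from compound 2 to compound 3 (0.02 log units; within the scatter). The other two measured steps, a step that the limit leaves unreadable from compound 1 to compound 2 and a step that the limit leaves unreadable from compound 1 to compound 3, give no size to work from. No shift beyond the scatter is therefore expected in this assay, and the expected step is a 1.0-fold lower number from compound 3 to compound 4 (0.02 log units; within the scatter). The estimated value for compound 4 is 52000 nM, with an expected range from 30000 nM to 90000 nM.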

Compound 4, half-maximal inhibitory concentration: 53000 nM
Compound 4: middle estimate off by 1.0-fold (0.01 log units), on the low side; the range from low to high includes it.
By their numbers in this assay, from the lowest: compounds 2, 4 and 3 (each within the scatter of the next).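

In this assay, the change from (2-acetamidoethyl)amino to 3-hydroxypyrrolidin-1-yl is a 1.0-fold lower number from compound 3 to compound 4 (0.01 log units; within the scatter), so the same exchange of groups now stays within the scatter with either configuration of the hydroxy-bearing ring carbon. Among these compounds, the configuration itself, which the earlier compounds did not vary, also leaves the number within the scatter, at a 1.0-fold higher number from compound 2 to compound 4 (0.02 log units; within the scatter). This pair tests configuration alone: the fact that compounds 2 and 4 differ only in the configuration as drawn.

As far as these compounds go, the steps from compound 1, which carries the carboxy group, cannot be read, so how that group compares with the others stays open: the limit of > 50000 nM in this assay, at which 1 of the 4 values shown sits. Also open, from the compounds shown here alone, is how this assay would respond to a primary amine or a longer chain on a saturated chain carbon bound to an aromatic carbon.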